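Swapping the Ring Nitrogen Substituent in a Substance-P Binder

A few compounds are considered here, and "the series" means these few. Any claim that something is new, unique, unknown or untested is made for them only; others in the source may bear on it.

Measured so far:
Compound 1 `C[C@@H](O[C@@H]1CN(C(=O)[C@@H]2COC(=O)N2)C[C@H]1c1ccc(F)cc1)c1cc(C(F)(F)F)cc(C(F)(F)F)c1` in an assay on CHO cells for displacement of a labelled ligand from Substance-P receptor (Homo sapiens) (a lower number here means a stronger inhibitor, a higher number a weaker inhibitor), gives 0.34 nM.
Compound 2 `C[C@@H](O[C@@H]1CN(C(=O)N2CCOCC2)C[C@H]1c1ccccc1)c1cc(C(F)(F)F)cc(C(F)(F)F)c1` in this assay gives 0.16 nM.

The two compounds share a common core and differ in more than one place, so their values show only where each stands. Compound 2 gives the lower of the two numbers; compound 1 sits higher by a gap that lies beyond the usual scatter of repeated measurements. Going by the values given here, no pair differing in a single place has been measured, so no isolated step is known.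

Compound 3 `C[C@@H](O[C@@H]1CN(C2=CC(=O)CC(C)(C)C2)C[C@H]1c1ccccc1)c1cc(C(F)(F)F)cc(C(F)(F)F)c1` has not yet been measured. It differs from compound 2 in one place: 5,5-dimethyl-3-oxocyclohex-1-en-1-yl in place of (morpholin-4-yl)carbonyl on an amine nitrogen in a ring. Among the compounds with values here, no measured pair speaks to this exchange. The group that leaves and the group that enters both carry a carbonyl and both sit on the same ring nitrogen, so the expected step in this assay is small, leaning toward a slightly higher number, and likely within the scatter. Compound 3 is therefore estimated at 0.4 nM, with a range from 0.1 nM to 2 nM. This estimate amounts to an expected step of a 2.5-fold higher number from compound 2 to compound 3 (0.40 log units; beyond the scatter).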

Compound 3, half-maximal inhibitory concentration: 0.13 nM
Beside the measured number, compound 3's estimate is 3.1-fold (0.49 log units) above it; the measured number falls inside the stated range.
By their numbers in this assay, from the lowest: compounds 3 and 2 (each within the scatter of the next); then compound 1.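

In this assay, placing 5,5-dimethyl-3-oxocyclohex-1-en-1-yl on the ring nitrogen in place of (morpholin-4-yl)carbonyl gives a 1.2-fold lower number from compound 2 to compound 3 (0.09 log units; within the scatter) and so leaves the reading effectively unchanged. For this pair, then, the position accepts a six-membered ring of carbon only, with 1 hydrogen-bond acceptor, as well as it accepts a six-membered ring with 2 hetero atoms and 2 hydrogen-bond acceptors, so neither the nitrogen nor the ring oxygen of the leaving group is needed to keep the number this low. No supporting measurement explains why two such different groups give matching numbers, so this remains an observation and not an explanation.

A single exchange cannot show which part of the entering group matters, and a plain cyclohexyl group with no carbonyl on the same ring nitrogen would test whether the carbonyl is needed at all. As far as these compounds go, how far this tolerance extends also remains open, since a small acetyl group or a piperidine ring joined through its nitrogen could mark out the size and type of group that the position accepts.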